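Stereochemical inversion of the side-chain in the chromene series

The compounds below may be only part of what the source reports. "The series", "measured", "known", "first", "only" and "open" are said of these compounds alone.

Going by the values given here, compound 1 `CC1=C(c2cccc(O)c2)C(c2ccc(OC[C@H](C)N3CC[C@H](C)C3)cc2)Oc2ccc(O)cc21` stands lowest of the three numbers so far in a functional assay on MCF7 cells (Homo sapiens) for antiproliferative activity, read by CellTiter-Glo, with a stated time of 5 days; on this read-out higher numbers stand for weaker inhibition and lower numbers for stronger inhibition: compound 1 gives 0.2 nM. Compound 3 `CC1=C(c2ccc(F)cc2)C(c2ccc(OC[C@H](C)N3CC[C@@H](C)C3)cc2)Oc2ccc(O)cc21` sits nearest, with 0.4 nM, a gap within the scatter, so the two are not ordered. Compound 2 `CC1=C(c2cccc(S(C)(=O)=O)c2)C(c2ccc(OC[C@H](C)N3CC[C@@H](C)C3)cc2)Oc2ccc(O)cc21` is furthest, with 4.3 nM, a gap beyond the scatter. Among the compounds with values here, the one single-point step available is an 11-fold lower number from compound 2 to compound 3 (1.03 log units; beyond the scatter), which concerns the aryl group on the double-bonded ring carbon and not the side chain.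

Compound 4 `CC1=C(c2cccc(O)c2)C(c2ccc(OC[C@@H](C)N3CC[C@@H](C)C3)cc2)Oc2ccc(O)cc21` differs from compound 1 only in stereochemistry: the two compounds have the same atoms and bonds; at least one stereo element is drawn with a configuration in one of them and without one in the other: 2 of 3 stereo elements differ; a stereocentre at a saturated chain carbon is drawn S in compound 1 and R in compound 4; a stereocentre at a saturated ring carbon is drawn S in compound 1 and R in compound 4. Within the data shown here, no measured step addresses a change of configuration, so the step from compound 1 to compound 4 has no direct precedent in these numbers. Compound 3 carries the ring-carbon configuration of compound 4 while keeping the chain configuration of compound 1. In this assay, from the compounds shown here alone, compound 3 gives 0.4 nM, which suggests the ring stereocentre alone matters little; the chain stereocentre is untested. A loss is expected but its size is uncertain, estimated as a 5.0-fold higher number from compound 1 to compound 4 (0.70 log units; beyond the scatter). Compound 4 is therefore expected to give 1 nM in this assay, with a range of 0.2 nM to 6 nM.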

Compound 4, half-maximal inhibitory concentration: 0.2 nM
For compound 4 the middle estimate is 5.0-fold (0.70 log units) above the measured one, and the stated range covers the measured number.
By their numbers in this assay, from the lowest: compounds 1, 4 and 3 (each within the scatter of the next); then compound 2.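

In this assay the change from S to R at both the saturated chain carbon and the saturated ring carbon reads as no change at the digits printed from compound 1 to compound 4 (within the scatter). Going by these compounds alone, this is the first step that addresses configuration, and it shows that these two stereocentres can change together with no reading beyond the scatter on this antiproliferative read-out, with the rest of the structure held constant. The reading is limited, since it rests on a pair whose stereochemistry is not drawn to the same extent: the fact that one of compounds 1 and 4 is drawn with a defined configuration and the other without, at the place where they differ

From the compounds shown here alone, what each stereocentre does alone remains open, as both change in this one step and opposing effects at the two carbons would give the same picture. Also open, going by these compounds, is whether the same result holds with the 4-fluorophenyl group on the double-bonded ring carbon, with an ethyl group in place of the methyl on the saturated chain carbon, or with a dimethylamine in place of the ring amine of the side chain.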